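Notes on the step to compound 4

This account rests on a few compounds, and the source may have more. Where it says the series, first, only, none or still open, it means among the compounds named here.

In an ADME assay on HepG2 cells (Homo sapiens) for cytotoxicity, with a stated time of 72 h (a higher number here means that more compound is needed for the effect, a lower number that less compound is needed), compound 1 (`Cc1cc(NC(=O)Nc2ccccc2N)c2ccccc2n1`) gives > 25000 nM as a limit of the assay. Compound 2 (`Cc1cc(NC(=O)Nc2cccc(N(C)C)c2)c2ccccc2n1`) gives > 25000 nM as a limit too. Compound 3 (`Cc1cc(NC(=O)Nc2ncccc2C)c2ccccc2n1`) stands at > 25000 nM as a limit as well. Within the data shown here, the series so far shows the limit of > 25000 nM in this assay, at which 3 of the 3 values shown sit, and no actual number.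

Compound 4 (`Cc1cc(NC(=O)Nc2cccc(Cl)c2)c2ccccc2n1`) carries 3-chlorophenyl in place of 3-methylpyridin-2-yl on an amide-type nitrogen, and the counted difference is 3-chlorophenyl in place of 3-methylpyridin-2-yl on an amide-type nitrogen with the shared core unchanged.

Among the measured compounds shown here, the one measured step that bears on this change is a step that the two limits leave unreadable from compound 1 to compound 3 and no size can be taken from it. With compound 3 at > 25000 nM as a limit and that step unreadable, the data give no ground for expecting a shift in either direction. The expected change in this assay is a number no higher from compound 3 to compound 4 (the limit leaves the size open) and nothing beyond the scatter is expected. For compound 4 the estimate is 25000 nM with an expected range from 10000 nM to 50000 nM and a further limit is the likeliest report.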

Compound 4, half-maximal effective concentration: 19000 nM
The estimate for compound 4 lay 1.3-fold (0.12 log units) above the measured number, within the range that was stated.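

Among these compounds, compound 4, at 19000 nM in this assay, gives the series its only actual number rather than a limit. Putting 3-chlorophenyl on the amide-type nitrogen gives an at least 1.3-fold lower number from compound 3 to compound 4 (0.11 log units; that floor lies within the scatter) and an at least 1.3-fold lower number from compound 1 to compound 4 (0.11 log units; that floor lies within the scatter), while chloro in place of dimethylamino on an aromatic carbon gives an at least 1.3-fold lower number from compound 2 to compound 4 (0.11 log units; that floor lies within the scatter). All three steps are floors, so this position may tolerate a change in the cytotoxicity read-out, but the true sizes remain unread, as the other values are still limits: the limit of > 25000 nM in this assay, at which 3 of the 4 values shown sit.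

The compounds shown do not separate the contribution of the chloro group from that of the carbon-only ring. Also open, on these data alone, is how the number would respond if a methoxy group, a carboxylic acid or a trifluoromethyl group stood in place of the chloro group on the same ring.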